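A few compounds are considered here, and "the series" means these few. Any claim that something is new, unique, unknown or untested is made for them only; others in the source may bear on it.

Measured in a physicochemical assay for lipophilicity, using the shake flask method, measured as octanol-water partition, at pH 7.4; a higher number here means a more lipophilic compound, a lower number a more polar compound:
- compound 1 `CC(=O)N[C@H]1[C@H]([C@@H](O)[C@H](O)CNC(=O)c2ccc(Cl)cc2)O[C@@](OCc2ccc(Cl)cc2)(C(=O)O)C[C@@H]1O`: 0.36
- compound 2 `CC(=O)N[C@H]1[C@H]([C@@H](O)[C@H](O)CNC(=O)c2ccc(Cl)cc2)O[C@@](OCc2ccc(F)cc2)(C(=O)O)C[C@@H]1O`: -0.11
- compound 3 `CC(=O)N[C@H]1[C@H]([C@@H](O)[C@H](O)CNC(=O)c2ccc(Cl)cc2)O[C@@](OCc2ccc3ccccc3c2)(C(=O)O)C[C@@H]1O`: 0.58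

Compound 3 stands level with compound 1 and clear of compound 2: a number 0.22 log units higher from compound 1 to compound 3 (within the scatter), and a number 0.69 log units higher from compound 2 to compound 3 (beyond the scatter). Compound 4 `CC(=O)N[C@H]1[C@H]([C@@H](O)[C@H](O)CNC(=O)c2ccc(Cl)cc2)O[C@@](OCc2cccc(Cl)c2Cl)(C(=O)O)C[C@@H]1O` differs from compound 3 in one group: 2,3-dichlorophenyl in place of naphthalen-2-yl on a saturated chain carbon bound to an oxygen on a saturated carbon, with 2,3-dichlorophenyl in place of naphthalen-2-yl. For the measured compounds named here, no measured step makes this exact exchange. Those two steps exchange naphthalen-2-yl against 4-chlorophenyl and 4-fluorophenyl. The remaining step, a number 0.47 log units lower from compound 1 to compound 2 (beyond the scatter), swaps fluoro for chloro on an aromatic carbon. Going by the size of that step, the second chlorine is expected to lift compound 4 modestly past compound 1, which gives a small rise from compound 3, no larger than the scatter. The expected change is a number 0.17 log units higher from compound 3 to compound 4 (within the scatter). Compound 4 is estimated at 0.75, with an expected range of 0.35 to 1.15.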

Compound 4, distribution coefficient: 0.53
For compound 4 the middle estimate is 0.22 log units above the measured one, and the stated range covers the measured number.
By their numbers in this assay, from the lowest: compound 2; then compounds 1, 4 and 3 (each within the scatter of the next).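

At this position, in this assay, 2,3-dichlorophenyl cannot be told apart from naphthalen-2-yl (a number 0.05 log units lower from compound 3 to compound 4 (within the scatter)) or from 4-chlorophenyl (a number 0.17 log units higher from compound 1 to compound 4 (within the scatter)), while it stands clear of 4-fluorophenyl (a number 0.64 log units higher from compound 2 to compound 4 (beyond the scatter)). Compounds 1, 3 and 4 thus form one level group despite their different aromatic groups, with only compound 2 going against it. Nothing available explains this level grouping.

The compounds shown leave open whether a phenyl ring carrying an amine or a nitrile would stay with that group or fall towards compound 2.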